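Hydroxyl removal and bromine loss on the benzamide ring

This account rests on a few compounds, and the source may have more. Where it says the series, first, only, none or still open, it means among the compounds named here.

Going by the values given here, compound 3 `O=C(Nc1ccc(Sc2nc3ccccc3s2)c(Cl)c1)c1cccc(Br)c1O` is the only member of the series with a numerical result: in an assay for inhibition of HSP60/HSP10 (Homo sapiens), with a stated time of 60 min (a higher number here means a weaker inhibitor, a lower number a stronger inhibitor), compound 3 gives 6900 nM. Compound 1 `COc1c(Br)cccc1C(=O)Nc1ccc(Sc2nc3ccccc3s2)c(Cl)c1` sits at a limit of the assay, as compound 1 gives > 100000 nM in this assay. Compound 2 `COc1ccc(Br)cc1C(=O)Nc1ccc(Sc2nc3ccccc3s2)cc1` likewise reaches only a limit, compound 2 giving > 100000 nM in this assay. Among the compounds with values here, the one measured step in this assay is an at least 14-fold lower number from compound 1 to compound 3 (1.16 log units; beyond the scatter); its size is bounded by the limit of > 100000 nM in this assay, at which 2 of the 3 values shown sit.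

Compound 4 `COc1ccccc1C(=O)Nc1ccc(Sc2nc3ccccc3s2)c(Cl)c1` differs from compound 3 as follows: 2-methoxyphenyl in place of 3-bromo-2-hydroxyphenyl on a carbonyl carbon. This change re-introduces the methyl on the oxygen that the step from compound 1 to compound 3 removed, and also drops the bromine. The measured step bears directly: reverting the hydroxyl to methoxy is expected to undo the large gain seen in an at least 14-fold lower number from compound 1 to compound 3 (1.16 log units; beyond the scatter). Compound 4 is therefore estimated at 150000 nM, with a range of 30000 nM to 600000 nM in this assay. The expected step is a 22-fold higher number from compound 3 to compound 4 (1.34 log units; beyond the scatter), most likely ending at a limit rather than a number.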

Compound 4, half-maximal inhibitory concentration: > 100000 nM
Compound 4: no number, only a limit; the forecaster's own chance of this, stated with the estimate: 75%; the middle value lies beyond the limit too.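

The change to 2-methoxyphenyl on the carbonyl carbon gives an at least 14-fold higher number from compound 3 to compound 4 (1.16 log units; beyond the scatter) in this assay, so this position now has a second comparison with compound 3, and that comparison also ends at the assay's limit. In this assay compound 4 gives > 100000 nM, a limit and not a number. The step between compound 1 and compound 4 cannot be read, but it does show that a methoxy ring with or without the bromine stays at the limit, leaving compound 3 as the only compound with a number: the limit of > 100000 nM in this assay, at which 3 of the 4 values shown sit.

The compounds shown leave open how much of the value of compound 3 belongs to the hydroxyl and how much to the bromine, since the step to compound 4 changes both. Also open, on these data alone, is whether an amine or a carboxylic acid in place of the hydroxyl would give a number.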